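Fluorophenyl Replaces Methoxyphenyl on the Indole Ketone

The source may report more compounds than this note shows. Statements on the series, on what has been measured and on what is new or still open speak of the compounds shown alone.

Measured compounds:
Compound 1, `COc1cccc(C(=O)c2ccc3c(ccn3S(=O)(=O)c3cccc(/C=C/C(=O)NO)c3)c2)c1`, 7740 nM
Compound 2, `COc1ccc(C(=O)c2ccc3c(ccn3Cc3ccc(C(=O)NO)cc3)c2)cc1`, 59800 nM
Compound 3, `COc1cc(C(=O)c2ccc3c(ccn3Cc3ccc(C(=O)NO)cc3)c2)cc(OC)c1OC`, "not determined" (no result reported)

In an assay on isolated protein for inhibition of polyamine deacetylase HDAC10 (Homo sapiens) (on this read-out higher numbers stand for weaker inhibition and lower numbers for stronger inhibition), compound 1 gives 7740 nM, the lowest of the two numbers available. Compound 2, which carries a different hydroxamate-bearing arm on the shared core, gives 59800 nM, a higher number that lies beyond the usual scatter of repeated measurements. For compound 3 the read-out is "not determined" (no result reported), so it adds nothing to the comparison. No two of the measured compounds differ in only one place, so no single-point step can be read from them.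

Compound 4, `O=C(/C=C/c1cccc(S(=O)(=O)n2ccc3cc(C(=O)c4ccc(F)cc4)ccc32)c1)NO`, is derived from compound 1 by one change: 4-fluorophenyl in place of 3-methoxyphenyl on a carbonyl carbon. The hydroxamate arm and the shared core are untouched. Among the compounds with values here, with no measured pair that shows how a change at the carbonyl-bound aryl group shifts the read-out, the expectation rests on the change being small and remote from the hydroxamate.

In this assay the expected step is a 1.0-fold higher number from compound 1 to compound 4 (0.01 log units; within the scatter), which is not beyond the scatter. Compound 4 is therefore estimated to give 8000 nM, with a range from 3000 nM to 22000 nM.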

Compound 4, half-maximal inhibitory concentration: 5240 nM
Compound 4: middle estimate off by 1.5-fold (0.18 log units), on the high side; measured number inside the range.
By their numbers in this assay, from the lowest: compounds 4 and 1 (each within the scatter of the next); then compound 2.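

In this assay, within the data shown here, the first step that isolates a single place in this set, 4-fluorophenyl in place of 3-methoxyphenyl on a carbonyl carbon, amounts to a 1.5-fold lower number from compound 1 to compound 4 (0.17 log units; within the scatter). The two compounds therefore cannot be told apart on this read-out, which shows that this position accepts an exchange of one aryl group for another with no change beyond the scatter, even though the hydrogen-bond acceptor counted in 3-methoxyphenyl leaves with it. No measurement shown here explains this outcome.

The step swaps the methoxy group for fluorine and moves the substituent in one stroke, so the compounds shown leave open which of these two differences matters, if either does, and whether a plain phenyl, an amine or a carboxylic acid on that ring would also stay within the scatter. Among these compounds, they also leave open whether the same exchange would behave alike with the other hydroxamate-bearing arm, since compound 2 differs from compound 1 and compound 4 in more than one place and forms no single-place pair with either.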